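The compounds below may be only part of what the source reports. "The series", "measured", "known", "first", "only" and "open" are said of these compounds alone.

Compound 1, `CC(C)(C)Cc1c(-c2ccncc2)sc(N)c1C(=O)c1ccc(Cl)cc1`: 6%
Compound 2, `CC(C)(C)Cc1c(-c2ccc(F)cc2)sc(N)c1C(=O)c1ccc(Cl)cc1`: 9%
Compound 3, `CC(C)(C)Cc1c(-c2ccc(Cl)c(Cl)c2)sc(N)c1C(=O)c1ccc(Cl)cc1`: 1%

All three compounds share one core and differ only in the aromatic group attached to one aromatic carbon of that core. In an assay on CHO cells for displacement of a labelled ligand from adenosine receptor A3 (Homo sapiens), read by scintillation counting, tested at 10 uM (a higher number here means more inhibition at the concentration tested (going by the name of the read-out), a lower number less inhibition), compound 3 gives the lowest of the three numbers, but its nearest neighbour is compound 1 with a number 5 percentage points lower from compound 1 to compound 3 (within the scatter) and its furthest is compound 2 with a number 8 percentage points lower from compound 2 to compound 3 (within the scatter), so the three values cannot be told apart.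

Compound 4, `Cc1noc(C)c1-c1sc(N)c(C(=O)c2ccc(Cl)cc2)c1CC(C)(C)C`, differs from compound 3 in one place: 3,5-dimethyl-1,2-oxazol-4-yl in place of 3,4-dichlorophenyl on an aromatic carbon. The measured steps that bear on this are the three exchanges of one aromatic group for another at the same place: a number 3 percentage points higher from compound 1 to compound 2 (within the scatter), a number 5 percentage points lower from compound 1 to compound 3 (within the scatter) and a number 8 percentage points lower from compound 2 to compound 3 (within the scatter). On these data alone, none of them introduces a five-membered ring with two hetero atoms, so the new group itself is untested here. Each of these steps is within the scatter, so for compound 4 the expected step is a number 4 percentage points higher from compound 3 to compound 4 (within the scatter), none beyond the scatter. Compound 4 is therefore estimated at 5%, with a range from -5% to 15%.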

Compound 4, a percentage reported as inhibition, at one concentration (the size of the read-out at that concentration, not a potency): 1%
The estimate for compound 4 lay 4 percentage points above the measured number; low and high end bracket the measured number.
By their numbers in this assay, from the lowest: compounds 3, 4, 1 and 2 (each within the scatter of the next).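

Among these compounds, the five-membered 3,5-dimethyl-1,2-oxazol-4-yl group is the first at this place without a six-membered aromatic ring, yet in this assay the steps are no change at the digits printed from compound 3 to compound 4 (within the scatter) and a number 8 percentage points lower from compound 2 to compound 4 (within the scatter) and a number 5 percentage points lower from compound 1 to compound 4 (within the scatter). Even this exchange of ring size and ring atoms, on the aromatic carbon next to the ring sulfur, therefore gives a number that cannot be told apart from the other three. No measurement shown offers an explanation for this result.

All four groups are aromatic rings, so an amine, a carboxylic acid or a saturated ring such as piperidine at this place remains an open case. The neopentyl and (4-chlorophenyl)carbonyl groups are also common to all four compounds, which leaves open what a shorter chain or an unsubstituted phenyl ring at those places would give.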